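A few compounds are considered here, and "the series" means these few. Any claim that something is new, unique, unknown or untested is made for them only; others in the source may bear on it.

In a physicochemical assay for lipophilicity, using the shake flask method, measured as octanol-water partition (a higher number here means a more lipophilic compound, a lower number a more polar compound), compound 1 `O=C(N/N=C/c1ccc(CO)cc1)c1ccncc1` gives 0.731, while compound 2 `O=C(N/N=C/c1ccc(Oc2ccccc2)cc1)c1ccncc1` gives 3.7, the higher of the two numbers. Compound 3 `O=Cc1ccc(/C=N/NC(=O)c2ccncc2)cc1`, not yet measured, keeps the shared core of compound 2 and changes one group: formyl in place of phenoxy on an aromatic carbon. Going by the values given here, only one measured step bears on this change: a number 2.97 log units higher from compound 1 to compound 2 (beyond the scatter), a large step that came with phenoxy in place of hydroxymethyl on an aromatic carbon. Compound 3 also gives up phenoxy, so a large fall in this assay is expected, toward compound 1 at 0.731. Among the compounds with values here, this expectation rests on a single pair, and no measured step involves formyl. The expected size of the change is a number 2.70 log units lower from compound 2 to compound 3 (beyond the scatter). For compound 3 the estimated value is 1, with an expected range from 0.5 to 1.6.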

Compound 3, partition coefficient: 1.32
For compound 3 the middle estimate is 0.32 log units below the measured one; the range from low to high includes it.
By their numbers in this assay, from the lowest: compound 1; then compound 3; then compound 2.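

At the aromatic carbon para to a large group, this assay now has a second comparison with phenoxy: formyl in its place gives a number 2.38 log units lower from compound 2 to compound 3 (beyond the scatter), a large step, so the high number of compound 2 does not carry over to this smaller group. The two groups without phenoxy can also be told apart, since formyl in place of hydroxymethyl gives a number 0.59 log units higher from compound 1 to compound 3 (beyond the scatter), a modest step. The position therefore responds to a change between formyl and hydroxymethyl, though far less than to the exchange of either for phenoxy.

From the compounds shown here alone, how an amine, a carboxylic acid or a longer alkyl chain would place at this position remains open, as does whether the same order would hold on another core. Nothing measured here explains the size of either step.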